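Pyridinyl for methylthiophene at the ether chain end

The source may report more compounds than this note shows. Statements on the series, on what has been measured and on what is new or still open speak of the compounds shown alone.

Compounds measured in an ADME assay on microsomes from liver (Homo sapiens) for metabolic stability, read by LC-MS, tested at 0.5 uM; a lower number here means that the compound disappears faster, a higher number that the compound lasts longer:
Compound 1 `COc1ccc(CCOc2ccc(-c3c(C)nc(C)c([C@H](OC(C)(C)C)C(=O)O)c3N3CCC(C)(C)CC3)cc2)cc1` gives > 2 h, a limit of the assay rather than a number.
Compound 2 `Cc1nc(C)c([C@H](OC(C)(C)C)C(=O)O)c(N2CCC(C)(C)CC2)c1-c1ccc(OCCc2ccc(F)cc2F)cc1` gives 1.08 h.
Compound 3 `Cc1ccc(CCOc2ccc(-c3c(C)nc(C)c([C@H](OC(C)(C)C)C(=O)O)c3N3CCC(C)(C)CC3)cc2)s1` gives > 2 h, again a limit of the assay rather than a number.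

Compound 3 thus stands at the limit, and the limit of > 2 h in this assay, at which 2 of the 3 values shown sit, describes where two of the three measured compounds sit. The step from compound 1 to compound 3 cannot be sized due to the limit of > 2 h in this assay, at which 2 of the 3 values shown sit. Compound 4 `Cc1nc(C)c([C@H](OC(C)(C)C)C(=O)O)c(N2CCC(C)(C)CC2)c1-c1ccc(OCCc2ccccn2)cc1` differs from compound 3 in one place: pyridin-2-yl in place of 5-methylthiophen-2-yl on a saturated chain carbon, two bonds along the chain from an oxygen on an aromatic ring. Of the measured steps, an at least 1.8-fold lower number from compound 1 to compound 2 (0.26 log units; that floor lies within the scatter) and an at least 1.8-fold higher number from compound 2 to compound 3 (0.26 log units; that floor lies within the scatter) show that the group at this chain end can move the half-life, while a step that the two limits leave unreadable from compound 1 to compound 3 stays unreadable. For the measured compounds named here, none of these steps exchanges a five-membered ring for a six-membered one, so no measured step bears directly on the change to compound 4. Compound 4 is therefore expected to sit close to compound 3. The expected step reads a number no higher from compound 3 to compound 4 (the limit leaves the size open). Compound 4 is estimated at 2 h, with a range from 1 h to 4 h.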

Compound 4, half-life: 0.5 h
Beside the measured number, compound 4's estimate is 4.0-fold (0.60 log units) above it; measured number below the stated range.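

In this assay, the group at the end of the ether chain now shows an effect that clearly exceeds the scatter, whereas the earlier readable steps gave only floors within it. Pyridin-2-yl in place of 5-methylthiophen-2-yl gives an at least 4.0-fold lower number from compound 3 to compound 4 (0.60 log units; beyond the scatter), and the same group in place of 4-methoxyphenyl gives an at least 4.0-fold lower number from compound 1 to compound 4 (0.60 log units; beyond the scatter). Even against the shorter-lived 2,4-difluorophenyl compound it gives a 2.2-fold lower number from compound 2 to compound 4 (0.33 log units; beyond the scatter), so compound 4 lasts the shortest time of the four, and the first two steps are floors rather than full sizes because compound 1 and compound 3 sit at a limit: the limit of > 2 h in this assay, at which 2 of the 4 values shown sit.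

The step between those two compounds cannot be read. Going by these compounds, whether a methylpyridinyl or a pyrimidinyl group at this chain end would behave like pyridin-2-yl, or last as long as 5-methylthiophen-2-yl, stays open.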